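A few compounds are considered here, and "the series" means these few. Any claim that something is new, unique, unknown or untested is made for them only; others in the source may bear on it.

Measured so far in a functional assay on MDA-MB-231 cells (Homo sapiens) for inhibition, read by MTT assay, with a stated time of 72 h; on this read-out lower numbers stand for stronger inhibition and higher numbers for weaker inhibition 
compound 1 (`CN(C)c1ccc(/C=C2/S/C(=N\c3nc4cc(-c5ccc(Cl)cc5)sc4s3)NC2=O)cc1`) gives "not determined" (no result reported) 
compound 2 (`Cc1ccc(/C=C2/S/C(=N\c3nc4cc(-c5ccc(Cl)cc5)sc4s3)NC2=O)cc1`) gives 22800 nM 
compound 3 (`O=C1N/C(=N/c2nc3cc(-c4ccc(Cl)cc4)sc3s2)S/C1=C/c1ccc(Cl)cc1`) gives "not determined" (no result reported) 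

In this assay compound 3 stands at "not determined" (no result reported) and so offers no number for comparison, and compound 1 is in the same position. Only compound 2 has a figure to work from.

Compound 4 (`O=C1N/C(=N/c2nc3cc(-c4ccc(Br)cc4)sc3s2)S/C1=C/c1ccc(Cl)cc1`) is compound 3 with a single change (bromo in place of chloro on an aromatic carbon), which puts bromo in place of chloro on an aromatic carbon, para to a large group. In other words, a 4-chlorophenyl becomes a 4-bromophenyl.

Among the measured compounds shown here, no measured pair here shows what this swap does. The expectation is therefore a step in this assay that stays within the usual scatter, with no direction favoured. With compound 3 lacking a number, the estimate leans on compound 2 at 22800 nM and its range is kept wide. For compound 4 the estimated half-maximal inhibitory concentration is 20000 nM with an expected range from 7000 nM to 60000 nM in this measurement.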

Compound 4, half-maximal inhibitory concentration: 22300 nM
Estimate against measurement, compound 4: 1.1-fold (0.05 log units) below; the range from low to high includes it.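

Compound 3 gives "not determined" (no result reported) and compound 4 gives 22300 nM in this assay so no step can be read between these two compounds. The compounds shown leave open what a 4-bromophenyl in place of a 4-chlorophenyl does to this read-out, and no other information here bears on the result.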